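Chloro for hydroxy on the core of compound 2

The source may report more compounds than this note shows. Statements on the series, on what has been measured and on what is new or still open speak of the compounds shown alone.

Three compounds of the series have been run in a functional assay on cells (Cancer cell lines, Homo sapiens) for cytotoxicity, with a stated time of 48 h; a lower number here means a stronger inhibitor of growth, a higher number a weaker inhibitor of growth. Compound 1 `COc1c(/C=C2/C(=O)Nc3ccc(Cl)cc32)c2ccccc2n1-c1ccccc1` gives 19100 nM. Compound 2 `COc1cc2c(/C=C3/C(=O)Nc4ccc(O)cc43)c(Cl)n(Cc3cc(OC)c(OC)c(OC)c3)c2cc1C` gives 34700 nM. Compound 3 `O=C1/C(=C/c2c(Cl)[nH]c3ccccc23)c2ccccc2N1Cc1ccccc1` gives 69200 nM. Among these three numbers compound 2 sits in the middle, yet its gaps to compound 1 and to compound 3 both lie within the usual scatter of repeated measurements, so the three readings cannot be told apart with confidence.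

Compound 4 `COc1cc2c(/C=C3/C(=O)Nc4ccc(Cl)cc43)c(Cl)n(Cc3cc(OC)c(OC)c(OC)c3)c2cc1C` has not yet been measured. It differs from compound 2 in one place: chloro in place of hydroxy on an aromatic carbon. For the measured compounds named here, no measured pair isolates this exchange, so no step for it can be drawn from the data. The expectation for this assay is a step no larger than the scatter, if anything toward a somewhat lower number. Compound 4 is estimated at 22000 nM, with a range of 8000 nM to 60000 nM. This estimate means an expected step of a 1.6-fold lower number from compound 2 to compound 4 (0.20 log units; within the scatter).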

Compound 4, concentration for total growth inhibition: 6030 nM
The estimate for compound 4 lay 3.6-fold (0.56 log units) above the measured number; measured number below the stated range.
By their numbers in this assay, from the lowest: compound 4; then compounds 1, 2 and 3 (each within the scatter of the next, the first and the last beyond it).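

In this assay, for the compounds shown here, this position on an aromatic carbon, meta to a fused ring and para to a fused ring, proves sensitive to substitution: chloro in place of hydroxy gives a 5.8-fold lower number from compound 2 to compound 4 (0.76 log units; beyond the scatter) and is the first exchange isolated by a measured pair. The exchange also removes the hydrogen-bond donor and acceptor counted for hydroxy, but this one pair cannot show whether the step follows from gaining chloro or from losing hydroxy. Nothing measured here explains the step.

An amine or a carboxylic acid at this position would help separate those two readings. From the compounds shown here alone, whether the step carries over to other cores remains open, as a single pair on the core of compound 2 cannot show it.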